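Fluoro in place of hydrogen on compound 1

The compounds below may be only part of what the source reports. "The series", "measured", "known", "first", "only" and "open" are said of these compounds alone.

Measured in an ADME assay (liver) for metabolic stability, with Liver microsome (Rattus norvegicus) as the target, using microsomes; on this read-out lower numbers stand for slow clearance and higher numbers for fast clearance
- compound 1 `Cc1cc2c(c(Oc3cccc(NS(=O)(=O)c4ccc(Cl)cc4)c3)n1)C(=O)N(C(C)C)C2=O` gives 250 mL.min-1.g-1
- compound 2 `Cc1cc2c(c(Oc3ccc(C)c(NS(=O)(=O)c4ccc(Cl)cc4)c3)n1)C(=O)N(C(C)C)C2=O` gives 131 mL.min-1.g-1

Only these two compounds have been measured, and they lie within the scatter of each other, so compound 1 holds no distinct rank. The change from compound 1 to compound 3 `Cc1cc2c(c(Oc3cc(NS(=O)(=O)c4ccc(Cl)cc4)ccc3F)n1)C(=O)N(C(C)C)C2=O` is fluoro in place of hydrogen on an aromatic carbon. Among the measured compounds shown here, the one measured step that bears on it is a 1.9-fold lower number from compound 1 to compound 2 (0.28 log units; within the scatter), for methyl in place of hydrogen on an aromatic carbon. For the measured compounds named here, that step involves a different group, and no measured compound carries fluoro, so it is only a loose guide. From the compounds shown here alone, no step beyond the scatter is therefore expected in this assay, and the direction stays open. The expected step is a 1.4-fold lower number from compound 1 to compound 3 (0.14 log units; within the scatter). The estimated value for compound 3 is 180 mL.min-1.g-1, with an expected range from 90 mL.min-1.g-1 to 320 mL.min-1.g-1.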

Compound 3, intrinsic clearance in microsomes: 84 mL.min-1.g-1
Beside the measured number, compound 3's estimate is 2.1-fold (0.33 log units) above it; the measured number lies below the stated range.
By their numbers in this assay, from the lowest: compounds 3, 2 and 1 (each within the scatter of the next, the first and the last beyond it).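

In this assay, among the compounds shown here, the step of a 3.0-fold lower number from compound 1 to compound 3 (0.47 log units; beyond the scatter) is the first to lie beyond the scatter, so the aromatic carbon para to the ((4-chlorophenyl)sulfonyl)amino group and ortho to a large group is a place where fluoro in place of hydrogen shifts the read-out by a modest but readable amount. The earlier step of a 1.9-fold lower number from compound 1 to compound 2 (0.28 log units; within the scatter) for methyl in place of hydrogen on an aromatic carbon could not show this, as it stays within the scatter. Nothing measured here bears on why the number falls at this carbon.

From the compounds shown here alone, whether chloro, methoxy or an amine on this same carbon gives a comparable step remains open. Going by these compounds, it is also open whether fluoro on the other aromatic carbons of this ring gives a step beyond the scatter.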